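Acyl swap from compound 3 to compound 4, working notes

A few compounds are considered here, and "the series" means these few. Any claim that something is new, unique, unknown or untested is made for them only; others in the source may bear on it.

Compound 1 `CCCn1c(NC(=O)c2ccccn2)nc2cc(C(N)=O)cc(OC)c21`: in an assay for activation of interferon regulatory factor 3 (Homo sapiens), read by a luciferase reporter, with a stated time of 20 h (on this read-out higher numbers stand for an effect only at larger amounts of compound and lower numbers for an effect already at smaller amounts), compound 1 gives only a limit of the assay, > 100000 nM.
Compound 2 `CCn1nc(C)cc1C(=O)Nc1nc2cc(C(=O)OC)cc(OC)c2n1CCCNC(=O)OCc1ccccc1`: in this assay compound 2 gives 27600 nM.
Compound 3 `COc1cc(C(N)=O)cc2nc(NC(=O)c3ccccn3)n(CCCNC(=O)OCc3ccccc3)c12`: in this assay compound 3 gives only a limit of the assay, > 100000 nM.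

Compound 3 therefore stands at the limit, as the limit of > 100000 nM in this assay, at which 2 of the 3 values shown sit, shows. Going by the values given here, the one measured step that reaches it, a step that the two limits leave unreadable from compound 1 to compound 3, is unreadable. Compound 4 `COc1cc(C(N)=O)cc2nc(NC(=O)C3CCN(C)CC3)n(CCCNC(=O)OCc3ccccc3)c12` differs from compound 3 by 1-methylpiperidin-4-yl in place of pyridin-2-yl on a carbonyl carbon. Among the compounds with values here, no measured step bears on this change; compound 2 carries another acyl group and an ester and is the only compound with a number, but no step joins it to compound 3. The expected step of a number no higher from compound 3 to compound 4 (the limit leaves the size open) is set so that compound 4 most likely stays at the limit. Compound 4 is expected at 100000 nM, in the range 30000 nM to 300000 nM.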

Compound 4, half-maximal effective concentration: > 100000 nM
Compound 4 gave a limit, no number (the forecaster's own chance of this, stated with the estimate: 70%); the middle value sits exactly at the limit.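

Compound 3 and compound 4 both give only a limit of the assay, so no step can be read between them. The compounds shown leave open whether any acyl group on their shared core gives a number.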